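The source may report more compounds than this note shows. Statements on the series, on what has been measured and on what is new or still open speak of the compounds shown alone.

Compound 1 `CN(Cc1cc(-c2ccccc2Cl)no1)C(=O)C1CCNCC1` gives 350 nM in an assay on isolated protein for positive allosteric modulation of Neuronal acetylcholine receptor; alpha4/beta2 (Homo sapiens); a lower number here means that less compound is needed, a higher number that more compound is needed for the effect.
Compound 2 `Clc1ccccc1-c1cc(-c2cnn(C3CCNCC3)c2)on1` gives 120 nM in this assay.

Compound 2 holds the lowest of these two numbers; compound 1 sits at a higher number, beyond the usual scatter. Compound 3 `Clc1cccc(Cl)c1-c1cc(-c2cnn(C3CCNCC3)c2)on1` is not yet measured. It differs from compound 2 by a single change: chloro in place of hydrogen on an aromatic carbon; one bond further out, this reads as 2-chlorophenyl to 2,6-dichlorophenyl. For the measured compounds named here, because no step between measured compounds is known, the expected step from compound 2 to compound 3 in this assay is no change at the digits printed from compound 2 to compound 3 (within the scatter), no change beyond the scatter. Compound 3 is therefore estimated at 120 nM, within 45 nM to 320 nM.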

Compound 3, half-maximal effective concentration: 410 nM
Beside the measured number, compound 3's estimate is 3.4-fold (0.53 log units) below it; measured number above the stated range.
By their numbers in this assay, from the lowest: compound 2; then compounds 1 and 3 (each within the scatter of the next).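

Going from 2-chlorophenyl to 2,6-dichlorophenyl gives a 3.4-fold higher number from compound 2 to compound 3 (0.53 log units; beyond the scatter) in this assay and so more compound is needed for the effect. For the compounds shown here, this aromatic carbon, ortho to a large group, therefore does not accept a chloro group as a neutral change, which the earlier compounds could not show. Nothing measured here explains this result.

The compounds shown leave open how a fluoro, methyl or methoxy group would behave on this same carbon. They also leave open whether adding this chloro group to compound 1 would produce a similar step.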